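Swapping the aryl group on the ring nitrogen

A few compounds are considered here, and "the series" means these few. Any claim that something is new, unique, unknown or untested is made for them only; others in the source may bear on it.

Of the compounds shown here, two have so far been measured in an assay on CHO cells for displacement of a labelled ligand from 5-hydroxytryptamine receptor 7 (Homo sapiens); a higher number here means a weaker inhibitor, a lower number a stronger inhibitor. Compound 1 `COc1ccc(S(=O)(=O)NCCCN2CCN(c3cccc(C(F)(F)F)c3)CC2)cc1` gives 89 nM, and compound 2 `COc1ccc(S(=O)(=O)NCCCN2CCN(c3ccc(C(F)(F)F)cc3)CC2)cc1` gives 384 nM, the higher of the two numbers. Going by the values given here, the single step between them, a 4.3-fold higher number from compound 1 to compound 2 (0.63 log units; beyond the scatter), exchanged 3-(trifluoromethyl)phenyl for 4-(trifluoromethyl)phenyl on the ring nitrogen.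

Compound 3 `COc1ccc(S(=O)(=O)NCCCN2CCN(c3cccc(OC)c3)CC2)cc1` has not yet been measured. It differs from compound 2 by 3-methoxyphenyl in place of 4-(trifluoromethyl)phenyl on an amine nitrogen in a ring. This change both returns to a 3-substituted phenyl, as in compound 1, and replaces the trifluoromethyl with a methoxy group, so the step of a 4.3-fold higher number from compound 1 to compound 2 (0.63 log units; beyond the scatter) bears on it only in part. On these data alone, that step raised the number when the substituent went from the 3-position to the 4-position; reversing the position is therefore expected to lower it, while the new group itself is untested here. Compound 3 is estimated at 110 nM, within 30 nM to 400 nM. This expectation corresponds to a 3.5-fold lower number from compound 2 to compound 3 (0.54 log units; beyond the scatter) in this assay.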

Compound 3, half-maximal inhibitory concentration: 339 nM
Beside the measured number, compound 3's estimate is 3.1-fold (0.49 log units) below it; low and high end bracket the measured number.
By their numbers in this assay, from the lowest: compound 1; then compounds 3 and 2 (each within the scatter of the next).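

With the position on the phenyl ring held fixed, methoxy in place of trifluoromethyl gives a 3.8-fold higher number from compound 1 to compound 3 (0.58 log units; beyond the scatter) in this assay, so a 3-substituted phenyl alone does not preserve the number of compound 1, and the group itself matters as well as where it sits. The other new step, a 1.1-fold lower number from compound 2 to compound 3 (0.05 log units; within the scatter), changes both the group and its position at once, and it leaves compound 2 and compound 3 indistinguishable in this assay. Nothing available here explains either step.

On these data alone, the pair of compounds with 4-methoxyphenyl and 3-methoxyphenyl on the ring nitrogen would show whether position matters for methoxy as it does for trifluoromethyl, and this remains open. As far as these compounds go, it is also open how a chlorine atom or a nitrile at this position would compare with trifluoromethyl.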